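Valine replaces lysine: an oral tail flick step forecast

This account rests on a few compounds, and the source may have more. Where it says the series, first, only, none or still open, it means among the compounds named here.

Compound 1 `O=C(O)CNC(=O)CN(c1nc(Cl)nc2[nH]cnc12)C1CC1`: 9.08%
Compound 2 `NCCCC[C@H](NC(=O)CN(c1nc(Cl)nc2[nH]cnc12)C1CC1)C(=O)O`: 11.6%

Of the compounds shown here, two built on a shared core have been tested in a functional assay on the whole organism (Tail, strain ICR) with Mus musculus as the target, in the tail flick test, with a stated time of 150 min, at a dose of 25 umol/kg by the oral route; on this read-out higher numbers stand for a stronger effect at the one dose given and lower numbers for a weaker effect. Compound 1 gives 9.08% and compound 2 gives 11.6%; the two numbers lie within the scatter of each other, so neither can be called the stronger. Among the measured compounds shown here, the only measured step, a number 2.5 percentage points higher from compound 1 to compound 2 (within the scatter), is within the scatter as well.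

Compound 3 `CC(C)[C@H](NC(=O)CN(c1nc(Cl)nc2[nH]cnc12)C1CC1)C(=O)O` is not yet measured. It differs from compound 2 by isopropyl in place of 4-aminobutyl on a saturated chain carbon bound to an amide-type nitrogen and a carbonyl carbon. For the measured compounds named here, the one step that bears on this position, a number 2.5 percentage points higher from compound 1 to compound 2 (within the scatter), shows that the group on this carbon made no difference beyond the scatter, so no step beyond the scatter is expected in this assay for compound 3. The estimate for compound 3 is 10%, with a range from 0% to 25%. The expected step is a number 1.6 percentage points lower from compound 2 to compound 3 (within the scatter).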

Compound 3, a percentage reported as activity, at one dose (the size of the read-out at that dose, not a potency): 7.86%
The estimate for compound 3 lay 2.1 percentage points above the measured number, and the stated range covers the measured number.
By their numbers in this assay, from the lowest: compounds 3, 1 and 2 (each within the scatter of the next).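

In this assay, isopropyl in place of 4-aminobutyl on a saturated chain carbon bound to an amide-type nitrogen and a carbonyl carbon gives a number 3.7 percentage points lower from compound 2 to compound 3 (within the scatter), and isopropyl in place of hydrogen on that carbon gives a number 1.2 percentage points lower from compound 1 to compound 3 (within the scatter). The earlier pair had compared only hydrogen with 4-aminobutyl; now a group with no nitrogen also stays within the scatter of both, so the amine of 4-aminobutyl is not required for the read-out to remain at this level. No measurement available here explains this result.

The compounds shown leave open whether any group on this carbon can move the read-out beyond the scatter, such as a benzyl group, a second carboxylic acid or a hydroxymethyl group. They also leave open what the opposite configuration at this carbon would give.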